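The source may hold more compounds than are shown below. What is called first, only, known or untested is meant among the compounds shown, and "the series" means these compounds.

Measured so far:
compound 1 `Cc1cc(Oc2ccc(/C=N/NC(=S)Nc3ccc(F)cc3)cc2)ccc1Cl` gives 6.07;
compound 2 `Fc1ccc(Oc2ccc(/C=N/NC(=S)Nc3ccc(Br)cc3)cc2)cc1` gives 5.82;
compound 3 `Cc1ccc(Oc2ccc(/C=N/NC(=S)Nc3ccc(F)cc3)cc2)cc1` gives 5.48.

Compound 3 stands lowest of the three numbers in a physicochemical assay for lipophilicity, in phosphate buffer, measured as octanol-water partition, with a stated time of 24 h; on this read-out lower numbers stand for lower lipophilicity and higher numbers for higher lipophilicity. Compound 2 lies nearest to it, with a higher value, and compound 1 lies furthest, higher still; both gaps are beyond the usual scatter.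

Compound 4 `Fc1ccc(NC(=S)N/N=C/c2ccc(Oc3ccc(F)cc3)cc2)cc1` is not yet measured. It differs from compound 3 by fluoro in place of methyl on an aromatic carbon. Among the measured compounds shown here, no measured step repeats this exact change. For the measured compounds named here, the one measured step that touches the same phenoxy ring is a number 0.59 log units lower from compound 1 to compound 3 (beyond the scatter), where loss of a chloro lowered this assay by a modest amount. Going by the values given here, compound 2 carries the same 4-fluorophenoxy group as compound 4 but a 4-bromophenyl on the thiourea instead of 4-fluorophenyl; the values of compound 2 and compound 3 show only that compound 2 sits higher, and no step between compound 2 and compound 4 has been measured.

On this basis a small downward move is expected, so that a number 0.33 log units lower from compound 3 to compound 4 (beyond the scatter) is estimated as the step from compound 3 to compound 4. Compound 4 is therefore expected to give about 5.15, within a range from 4.85 to 5.45.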

Compound 4, partition coefficient: 5.19
Estimate against measurement, compound 4: 0.04 log units below, within the range that was stated.
By their numbers in this assay, from the lowest: compounds 4 and 3 (each within the scatter of the next); then compounds 2 and 1 (each within the scatter of the next).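

In this assay, among the compounds shown here, the change from 4-methylphenoxy to 4-fluorophenoxy stands alone for the first time, and a number 0.29 log units lower from compound 3 to compound 4 (within the scatter) shows that methyl and fluoro on this aromatic carbon, para to a large group, are not told apart by this read-out. The other two steps are both larger than the usual scatter: swapping the bromo for a fluoro gives a number 0.63 log units lower from compound 2 to compound 4 (beyond the scatter) on the thiourea side, while 4-fluorophenyl in place of 4-chloro-3-methylphenyl on the oxygen gives a number 0.88 log units lower from compound 1 to compound 4 (beyond the scatter) on the phenoxy side. No independent measurement is available to account for the size of any of these steps.

The compounds shown leave open whether methyl and fluoro would still read alike in this assay with 4-bromophenyl in place of 4-fluorophenyl on the thiourea, since that pair is not among them. They also leave open how far the number would move with an amine, a carboxylic acid or a longer chain on this same aromatic carbon.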